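The compounds below may be only part of what the source reports. "The series", "measured", "known", "first", "only" and "open" are said of these compounds alone.

Measured compounds:
Compound 1 `O=C(O)CCNC(=O)c1ccc(C(Oc2ccc(-n3cc(C(F)(F)F)cn3)cc2)C2CC2)cc1` — in a functional assay on cells for antagonist activity at Glucagon receptor (Homo sapiens), read by cAMP accumulation, in the presence of a further agent that is not named here (on this read-out lower numbers stand for stronger inhibition and higher numbers for weaker inhibition), compound 1 gives 15000 nM.
Compound 2 `O=C(O)CCNC(=O)c1ccc(C(Oc2ccc(-n3cc(C(F)(F)F)cn3)cc2)C2CCCC2)cc1` — in this assay compound 2 gives 4000 nM.

Within the data shown here, compound 2 holds the lower of the two numbers, and the single measured step, a 3.8-fold lower number from compound 1 to compound 2 (0.57 log units; beyond the scatter), is modest yet beyond the scatter. Compound 3 `CC(C)(C)C(Oc1ccc(-n2cc(C(F)(F)F)cn2)cc1)c1ccc(C(=O)NCCC(=O)O)cc1` differs from compound 2 by tert-butyl in place of cyclopentyl on a saturated chain carbon bound to an aromatic carbon and an oxygen on an aromatic ring. Among the measured compounds shown here, no measured step involves a tert-butyl group, so the step from cyclopropyl to cyclopentyl is the only guide, and it shows that the group on this carbon does shift the number. A step of at most similar size is expected for compound 3, written as a 1.6-fold lower number from compound 2 to compound 3 (0.20 log units; within the scatter). Compound 3 is estimated at 2500 nM, with a range from 800 nM to 8000 nM.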

Compound 3, antagonist equilibrium constant: 4300 nM
Estimate against measurement, compound 3: 1.7-fold (0.24 log units) below, and the stated range covers the measured number.
By their numbers in this assay, from the lowest: compounds 2 and 3 (each within the scatter of the next); then compound 1.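

In this assay, tert-butyl and cyclopentyl cannot be told apart on this carbon (a 1.1-fold higher number from compound 2 to compound 3 (0.03 log units; within the scatter)), so a ring at this place is not required for the number seen with compound 2. Tert-butyl also stands clear of cyclopropyl (a 3.5-fold lower number from compound 1 to compound 3 (0.54 log units; beyond the scatter)), which gives a second group, beside cyclopentyl, with a lower number than cyclopropyl. No supporting measurement is available to explain these steps. Still open, going by these compounds, is how isopropyl, a smaller open chain, or cyclohexyl, a larger ring, would read on this carbon. An amine at this place also remains untested among the compounds shown here.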